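The source may hold more compounds than are shown below. What is called first, only, known or untested is meant among the compounds shown, and "the series" means these compounds.

Compound 2 `CS(=O)(=O)Nc1ccc2c(c1)S(=O)(=O)N=C(C1=C(O)C3CCCC3N(Cc3ccccn3)C1=O)N2` has been tested in an ADME assay on Huh-7 cells (Homo sapiens) for cytotoxicity, with a stated time of 72 h; on this read-out higher numbers stand for lower toxicity in this test and lower numbers for higher toxicity in this test. In this assay compound 2 gives > 33000 nM, which is a limit of the assay rather than a number. Compound 1 `CS(=O)(=O)Nc1ccc2c(c1)S(=O)(=O)N=C(C1=C(O)C3CCCC3N(CCC3CC3)C1=O)N2` likewise returns a limit in this assay, where compound 1 gives > 33000 nM. Both measurements sit at the limit of > 33000 nM in this assay, at which 2 of the 2 values shown sit, so the step from compound 1 to compound 2 (a step that the two limits leave unreadable from compound 1 to compound 2) cannot be read. Compound 3 `CS(=O)(=O)Nc1ccc2c(c1)S(=O)(=O)N=C(C1=C(O)C3CCCC3N(Cc3ccccc3)C1=O)N2` has not yet been measured. It differs from compound 2 in one place: phenyl in place of pyridin-2-yl on a saturated chain carbon bound to an amide-type nitrogen in a ring. Within the data shown here, the only measured step touches the same position, but it runs between two limits (a step that the two limits leave unreadable from compound 1 to compound 2), so its size is unknown and nothing readable bears on this change. Since compound 2 sits at the limit of > 33000 nM in this assay, at which 2 of the 2 values shown sit, compound 3 is expected to return a limit as well, and the estimated step from compound 2 to compound 3 (a number no higher from compound 2 to compound 3 (the limit leaves the size open)) is none beyond the scatter. Compound 3 is estimated at 33000 nM, with a range from 20000 nM to 60000 nM.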

Compound 3, half-maximal cytotoxic concentration: > 33000 nM
Compound 3: no number, only a limit; the forecaster's own chance of this, stated with the estimate: 90%; the middle value lies on the limit itself.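

In this assay compound 3 gives > 33000 nM, again a limit and not a number, so no step to it from compound 1 or compound 2 can be read: the limit of > 33000 nM in this assay, at which 3 of the 3 values shown sit.

Left open is whether cyclopropylmethyl, pyridin-2-yl and phenyl differ at all in this assay, and at what concentration compound 1, compound 2 or compound 3 would become toxic.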